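This account rests on a few compounds, and the source may have more. Where it says the series, first, only, none or still open, it means among the compounds named here.

Measured compounds:
compound 1 `CC(=O)c1ccc2c(c1)N(C1=CCCC1=O)CC(C)(C)S2`: 77%
compound 2 `CC(=O)Nc1ccc2c(c1)N(C1=CCCC1=O)CC(C)(C)S2`: "not determined" (no result reported)

In a functional assay on aorta (Rattus norvegicus, strain Wistar), in the presence of a further agent that is not named here (on this read-out higher numbers stand for larger maximal responses and lower numbers for smaller maximal responses), compound 1 gives 77%. For compound 2 the same read-out was recorded as "not determined" (no result reported), so compound 2 has no single number in this assay and stands nowhere on the numbers shown; the only fixed point of the series is compound 1.

Compound 3 `CC1(C)CN(C2=CCCC2=O)c2cc(C(F)(F)F)ccc2S1` is not yet measured. It differs from compound 2 by trifluoromethyl in place of acetamido on an aromatic carbon. Among the measured compounds shown here, no step between two measured compounds is available to gauge what this change does in this assay; the one measured anchor is compound 1, which reaches 77%. For the measured compounds named here, with no measured pair to set a direction, no shift beyond the usual scatter is assumed either way, and the uncertainty is wide. Compound 3 is expected to reach about 72% in this assay, estimated within 45% to 95%.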

Compound 3, largest response reached (Emax), in percent of the reference or control that the assay uses: 96%
Estimate against measurement, compound 3: 24 percentage points below; the whole stated range lies below it.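

In this assay, trifluoromethyl in place of acetyl on this aromatic carbon, meta to a fused ring and para to a fused ring, gives a number 19 percentage points higher from compound 1 to compound 3 (beyond the scatter), so the maximal response at this position depends on the group it carries, and a group without a carbonyl is compatible with the larger response. The step from compound 2 to compound 3 cannot be read, since compound 2 has no number, and acetamido therefore stays unplaced relative to the other two groups. No measured property of these groups accompanies the step, and the reason for it remains unexplained.

A single readable step cannot show whether the change follows from trifluoromethyl entering or from acetyl leaving. From the compounds shown here alone, whether a nitrile, a chlorine atom or a carboxylic acid on the same aromatic carbon would track compound 3 or compound 1 remains open.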